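The source may report more compounds than this note shows. Statements on the series, on what has been measured and on what is new or still open speak of the compounds shown alone.

Compound 1 `COc1cccc(CNCCCNc2ccnc3cc(Oc4ccc(Cl)cc4)ccc23)c1O` gives 9.28 in a physicochemical assay for acid dissociation. Compound 2 `Fc1ccc(Cc2ccc3c(NCCCNCc4ccco4)ccnc3c2)c(Cl)c1` gives 9.47. Compound 3 `COc1cccc(CNCCCNc2ccnc3cc(-c4cc(C(F)(F)F)cc(C(F)(F)F)c4)ccc23)c1O` gives 9.47.

Among these three, compound 1 has the lowest number, but the gaps to compound 2 and to compound 3 both fall within the usual scatter, so the three values cannot be told apart. Compound 4 `COc1cccc(CNCCCNc2ccnc3cc(CC4CCCCC4)ccc23)c1O` has not yet been measured. It differs from compound 1 in one place: cyclohexylmethyl in place of 4-chlorophenoxy on an aromatic carbon. The change sits on the fused ring system, away from the amine whose proton is measured. Within the data shown here, no step between measured compounds is available for comparison. The expected step from compound 1 to compound 4 is a number 0.07 log units higher from compound 1 to compound 4 (within the scatter), no more than the scatter. Compound 4 is therefore estimated at 9.35, with a range from 9 to 9.7.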

Compound 4, acid dissociation constant: 9.47
Estimate against measurement, compound 4: 0.12 log units below; the measured number falls inside the stated range.
By their numbers in this assay, from the lowest: compounds 1, 2, 3 and 4 (each within the scatter of the next).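

In this assay, cyclohexylmethyl in place of 4-chlorophenoxy on this aromatic carbon gives a number 0.19 log units higher from compound 1 to compound 4 (within the scatter). Among these compounds, this is the first direct comparison at this position, and replacing a chlorine-bearing aromatic ring with a non-aromatic ring of carbon only leaves the two numbers indistinguishable. Nothing available explains this result. Only these two groups have been compared at this position, so the step says nothing about other groups. On these data alone, whether an amine or a carboxylic acid on the same carbon would give a step beyond the scatter remains open.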